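Furan-2-yl in place of pyrazole on the shared core

The source may report more compounds than this note shows. Statements on the series, on what has been measured and on what is new or still open speak of the compounds shown alone.

Among the measured compounds shown here, compound 2 `OC[C@H]1OC(n2cnc3c(-c4cc[nH]n4)ncnc32)[C@H](O)[C@@H]1O` is one of two compounds measured so far: in a functional assay on L1210 cells (Mus musculus) for inhibition (on this read-out lower numbers stand for stronger inhibition and higher numbers for weaker inhibition), compound 2 gives 19800 nM, the highest of the two numbers, while compound 1 `OC[C@H]1OC(n2cnc3c(-c4nccs4)ncnc32)[C@H](O)[C@@H]1O` gives 16000 nM in this assay. For the measured compounds named here, the single measured step, a 1.2-fold higher number from compound 1 to compound 2 (0.09 log units; within the scatter), lies within the scatter, so the two five-membered aromatic rings tried so far do not separate. Compound 3 `OC[C@H]1OC(n2cnc3c(-c4ccco4)ncnc32)[C@H](O)[C@@H]1O` differs from compound 2 by one change, (furan-2-yl in place of 1H-pyrazol-3-yl on an aromatic carbon). Going by the values given here, no measured step covers this exact exchange; the one step available, a 1.2-fold higher number from compound 1 to compound 2 (0.09 log units; within the scatter), also exchanges the five-membered aromatic ring on the shared core and brings no shift beyond the scatter, so in this assay the step of a 1.1-fold lower number from compound 2 to compound 3 (0.04 log units; within the scatter) is expected to stay within the scatter as well. For compound 3 the estimate in this assay is 18000 nM, with a range from 7000 nM to 45000 nM.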

Compound 3, half-maximal inhibitory concentration: 2000 nM
For compound 3 the middle estimate is 9.0-fold (0.95 log units) above the measured one; the whole stated range lies above it.
By their numbers in this assay, from the lowest: compound 3; then compounds 1 and 2 (each within the scatter of the next).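

In this assay the choice of five-membered aromatic ring on this aromatic carbon of the shared core does matter: furan-2-yl gives a 9.9-fold lower number from compound 2 to compound 3 (1.00 log units; beyond the scatter) and an 8.0-fold lower number from compound 1 to compound 3 (0.90 log units; beyond the scatter) and so sets compound 3 apart from both earlier compounds, which did not separate from each other. The position therefore responds to this exchange even though 1H-pyrazol-3-yl and 1,3-thiazol-2-yl gave no difference there. Nothing available explains why furan-2-yl differs from the other two rings.

The compounds shown leave open whether this gain belongs to furan-2-yl alone or extends to related rings such as thiophene, furan-3-yl or a phenyl ring. They also do not show how a non-ring group on this carbon, such as an amine or a short alkyl chain, would compare.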